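The source may report more compounds than this note shows. Statements on the series, on what has been measured and on what is new or still open speak of the compounds shown alone.

Working notes on the series.

Compound 1 `Cc1ccccc1NC(=O)Nc1cc(C(C)(C)C)nn1-c1ccccc1` and compound 2 `COc1cccc(NC(=O)Nc2cc(C(C)(C)C)nn2-c2ccccc2)c1` share one core and differ only in the aryl group on the amide-type nitrogen. For the measured compounds named here, in an assay on isolated protein for inhibition of Ephrin type-A receptor 2 (Homo sapiens), read by thermal shift assay, tested at 10 uM (a lower number here means that the compound stabilises the target less, a higher number that the compound stabilises the target more against heat), compound 1 gives 1.2 degrees C, and compound 2 gives 1.8 degrees C. The step of a number 0.60 degrees C higher from compound 1 to compound 2 (within the scatter) is the only measured step so far. Compound 2 thus holds the higher of the two numbers, though its gap to compound 1 lies within the scatter, so no order between the two can be claimed.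

Compound 3 `CC(C)(C)c1cc(NC(=O)Nc2cc(F)cc(F)c2)n(-c2ccccc2)n1` is the next member to be measured. Its change from compound 2 is 3,5-difluorophenyl in place of 3-methoxyphenyl on an amide-type nitrogen. Going by the values given here, the one measured step, from compound 1 to compound 2, also exchanged the aryl group on this nitrogen and stayed within the scatter; no measured step covers the entry of two fluorine atoms in place of the methoxy group. On this basis the expected step of a number 0.30 degrees C lower from compound 2 to compound 3 (within the scatter) in this assay is none beyond the scatter, in either direction. Compound 3 is therefore estimated at 1.5 degrees C, with a range from 0.3 degrees C to 2.8 degrees C.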

Compound 3, shift of the target's melting temperature: 2.7 degrees C
Estimate against measurement, compound 3: 1.2 degrees C below; the range from low to high includes it.
By their numbers in this assay, from the lowest: compounds 1, 2 and 3 (each within the scatter of the next, the first and the last beyond it).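

On the amide-type nitrogen, 3,5-difluorophenyl in place of 3-methoxyphenyl gives, in this assay, a number 0.90 degrees C higher from compound 2 to compound 3 (within the scatter), so this exchange alone cannot be separated from the scatter of repeated measurements. Against 2-methylphenyl, the same 3,5-difluorophenyl group gives a number 1.5 degrees C higher from compound 1 to compound 3 (beyond the scatter), the first step in the series to pass the scatter and the first sign that the aryl group at this position can change the read-out, though modestly, while compound 2 stays within the scatter of both neighbours and so allows no finer ranking. No measurement is available that bears on the origin of this difference.

The compounds shown leave open whether a single fluorine atom, a chlorine atom or a trifluoromethyl group on the phenyl ring would give a similar number, and whether an amine or a carboxylic acid there would be tolerated. They also leave open how much the rest of the shared core contributes, since all three compounds vary only in the aryl group on this nitrogen.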